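The source may report more compounds than this note shows. Statements on the series, on what has been measured and on what is new or still open speak of the compounds shown alone.

Compound 1 `CN(C(=O)NC(=O)c1ccc(C(F)(F)F)cc1)c1nc(C(F)(F)F)c(C(=O)N/N=C/c2ccc(C(F)(F)F)cc2)s1` in a functional assay on A549 cells (Homo sapiens) for inhibition, read by MTT assay, with a stated time of 72 h (on this read-out lower numbers stand for stronger inhibition and higher numbers for weaker inhibition), gives > 100 ug/mL, which is a limit of the assay rather than a number.
Compound 2 `CNc1nc(C)c(C(=O)N/N=C/c2ccc(C(F)(F)F)cc2)s1` in this assay gives > 100 ug/mL, also a limit.
Compound 3 `CN(C(=O)NC(=O)c1ccccc1F)c1nc(C(F)(F)F)c(C(=O)N/N=C/c2ccc(C(F)(F)F)cc2)s1` in this assay gives 5.68 ug/mL.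

Compound 3 therefore stands as the only one of the three with a measured number; the other two sit at the limit of > 100 ug/mL in this assay, at which 2 of the 3 values shown sit. Going by the values given here, the single measured step, an at least 17-fold lower number from compound 1 to compound 3 (1.24 log units; beyond the scatter), is large and shows how strongly the inhibition can move with a change on the carbonyl carbon at the end of the acyl urea arm.

Compound 4 `CNc1nc(C(F)(F)F)c(C(=O)N/N=C/c2ccc(C(F)(F)F)cc2)s1` differs from compound 3 by hydrogen in place of ((2-fluorophenyl)carbonyl)carbamoyl on a nitrogen on an aromatic ring, so the whole acyl urea arm is removed. Among the compounds with values here, no measured step follows exactly this change. Compound 2, which also carries a hydrogen on that nitrogen but a methyl instead of a trifluoromethyl on the core, gives > 100 ug/mL, a limit. Compound 4 is thus expected to behave more like compound 2 than like compound 3. The step of a 14-fold higher number from compound 3 to compound 4 (1.15 log units; beyond the scatter) is expected to be a clear loss of inhibition. Compound 4 is estimated at about 80 ug/mL, with a range from 20 ug/mL to 300 ug/mL, and a fair chance that only a limit is reported.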

Compound 4, half-maximal inhibitory concentration: > 100 ug/mL
Compound 4: a limit, no number (the forecaster's own chance of this, stated with the estimate: 65%); at least 1.2-fold (0.09 log units) between middle value and limit.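

In this assay, taking the whole ((2-fluorophenyl)carbonyl)carbamoyl arm off the nitrogen on the aromatic ring and leaving a hydrogen there gives an at least 17-fold higher number from compound 3 to compound 4 (1.24 log units; beyond the scatter), so on this core the measured inhibition needs the arm to be present. Going by these compounds alone, the earlier step showed only that the group at the far end of the arm matters; together the two changes show that the arm alone is not enough, since compound 1 carries it and still gives only a limit, and that losing it entirely also ends at a limit. Compound 4 likewise gives a limit and not a number: the limit of > 100 ug/mL in this assay, at which 3 of the 4 values shown sit.

From the compounds shown here alone, the change from compound 2 to compound 4, trifluoromethyl in place of methyl on an aromatic carbon, cannot be read, as both values are limits, so what that group does on the core remains open. Also open, going by these compounds, is whether a smaller group on that nitrogen, such as a simple acetyl, keeps any inhibition, and whether a plain phenyl without fluorine at the end of the arm does as well as the 2-fluorophenyl.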